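This account rests on a few compounds, and the source may have more. Where it says the series, first, only, none or still open, it means among the compounds named here.

Compound 1 `CC1=NN(C(=O)CCl)C(c2cc(Br)ccc2O)C1`: 13500 nM
Compound 2 `O=C(c1ccccc1)N1N=C(c2cc3ccccc3oc2=O)CC1c1ccccc1`: 12700 nM

In a functional assay on MGC-803 cells (Homo sapiens) for cytotoxicity, read by MTT assay, with a stated time of 48 h (a higher number here means a weaker inhibitor, a lower number a stronger inhibitor), compound 2 gives 12700 nM and compound 1 gives 13500 nM, so the two stand within the usual scatter of each other. Compound 3 `CCNCC(=O)N1N=C(c2cc3ccccc3oc2=O)CC1c1ccccc1` keeps the core of compound 2 and swaps one group: (ethylamino)methyl in place of phenyl on a carbonyl carbon. In words, (ethylamino)methyl comes in place of phenyl on a carbonyl carbon. For the measured compounds named here, no measured pair shows what such a swap does, so any forecast is loose. A modest move toward a lower number, about the size of the scatter, is expected: a 1.6-fold lower number from compound 2 to compound 3 (0.20 log units; within the scatter). Compound 3 is estimated at 8000 nM, with an expected range of 2000 nM to 30000 nM.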

Compound 3, half-maximal inhibitory concentration: 26600 nM
Estimate against measurement, compound 3: 3.3-fold (0.52 log units) below, and the stated range covers the measured number.
By their numbers in this assay, from the lowest: compounds 2, 1 and 3 (each within the scatter of the next, the first and the last beyond it).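

In this assay, placing (ethylamino)methyl in place of phenyl on a carbonyl carbon gives a 2.1-fold higher number from compound 2 to compound 3 (0.32 log units; beyond the scatter). For the compounds shown here, this is the first pair here that differs in one place, and it shows that the group at this position can shift the number, with phenyl the better of these two. The swap removes an aromatic ring and brings in a nitrogen with a hydrogen-bond donor, and nothing at hand says which of these changes matters. Still open, from the compounds shown here alone, is whether a pyridine ring in place of phenyl, or a morpholine in place of the ethylamino part, would move the number, and in which direction.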